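Fluoro to methoxy: what to expect for compound 3

The source may hold more compounds than are shown below. What is called first, only, known or untested is meant among the compounds shown, and "the series" means these compounds.

compound 1 `O=C(OC1CCC(CN2CCN(c3cc(=O)c4cc(C(F)(F)F)cc([N+](=O)[O-])c4s3)CC2)CC1)c1ccncc1`: 1%
compound 2 `O=C(OC1CCC(CN2CCN(c3cc(=O)c4cc(C(F)(F)F)cc([N+](=O)[O-])c4s3)CC2)CC1)c1ccc(F)cc1`: 3%

In an ADME assay on cells (Hepatocyte, Homo sapiens) for metabolic stability, with a stated time of 30 min (on this read-out lower numbers stand for a less stable compound and higher numbers for a more stable compound), compound 2 gives 3%, level with compound 1 within the scatter, and both numbers sit low on this scale. Compound 3 `COc1ccc(C(=O)OC2CCC(CN3CCN(c4cc(=O)c5cc(C(F)(F)F)cc([N+](=O)[O-])c5s4)CC3)CC2)cc1` differs from compound 2 at one place: methoxy in place of fluoro on an aromatic carbon. Among the compounds with values here, the only measured step, a number 2 percentage points higher from compound 1 to compound 2 (within the scatter), also changes the aromatic ring on the carbonyl carbon and stays small. No change beyond the scatter is therefore expected in this assay. The expected step is no change at the digits printed from compound 2 to compound 3 (within the scatter). Compound 3 is estimated at 3%, with an expected range of 1% to 12%.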

Compound 3, percent of the compound remaining: 12.2%
Compound 3: the middle estimate sits 9.2 percentage points below what was measured, outside the stated range (above it).
By their numbers in this assay, from the lowest: compounds 1, 2 and 3 (each within the scatter of the next, the first and the last beyond it).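

In this assay, methoxy in place of fluoro gives a number 9.2 percentage points higher from compound 2 to compound 3 (within the scatter) and so cannot be told apart from repeat-measurement noise, even though it is the largest single-substituent step seen at this ring position. Set against the pyridin-4-yl ester, the 4-methoxyphenyl ester gives a number 11.2 percentage points higher from compound 1 to compound 3 (beyond the scatter) and this is the first step here to clear the scatter, showing that the aromatic group on this carbonyl carbon can shift the read-out modestly. No measurement shown gives a reason for this shift.

Still open, as far as these compounds go, is whether an amine or a longer alkoxy chain at this place on the ring would shift the number further. From the compounds shown here alone, it is also open whether the same step would hold with the ester replaced by an amide.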